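This account rests on a few compounds, and the source may have more. Where it says the series, first, only, none or still open, it means among the compounds named here.

Compound 1 `COc1cc(/C=C/C(=O)/C=C/c2cc(OC)c(OC)c(OC)c2)ccc1OCc1cn(CCOc2cc(=O)oc3ccccc23)nn1` carries three methoxy groups on one of the two aryl rings that flank the central dienone. In a functional assay on HCT-116 cells (Homo sapiens) for inhibition, read by sulforhodamine B assay, with a stated time of 48 h, tested at 50 uM (on this read-out higher numbers stand for more inhibition of growth at the one concentration tested and lower numbers for less inhibition of growth), compound 1 gives 89%. Compound 2 `COc1ccc(/C=C/C(=O)/C=C/c2ccc(OCc3cn(CCOc4cc(=O)oc5ccccc45)nn3)c(OC)c2)cc1OC` differs from it by a single change, (hydrogen in place of methoxy on an aromatic carbon), and in this assay compound 2 gives 82%; the step of a number 7 percentage points lower from compound 1 to compound 2 (within the scatter) is therefore small, and the two numbers are best treated as the same.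

Compound 3 `COc1ccccc1/C=C/C(=O)/C=C/c1ccc(OCc2cn(CCCCCOc3cc(=O)oc4ccccc34)nn2)c(OC)c1` belongs to a different core: the difference between the core of compound 1 and that of compound 3 is not broken down here. In this assay compound 3 gives 33%, which is well apart from the two other numbers.

Compound 4 `COc1cc(/C=C/C(=O)/C=C/c2ccccc2)ccc1OCc1cn(CCCCCOc2cc(=O)oc3ccccc23)nn1` has not yet been measured. It is made from compound 3 by hydrogen in place of methoxy on an aromatic carbon. Among the measured compounds shown here, this is the same kind of change as the one from compound 1 to compound 2, but not the same: there the leaving methoxy sat ortho to a methoxy group, meta to a large group and meta to a methoxy group, whereas here it sits ortho to a large group. Because the step of a number 7 percentage points lower from compound 1 to compound 2 (within the scatter) stayed within the scatter, a similarly small step is expected here, namely a number 2 percentage points higher from compound 3 to compound 4 (within the scatter). Compound 4 is expected to give about 35% in this assay, with a range from 15% to 60% that is anchored on the number for compound 3 33%.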

Compound 4, percent growth inhibition at one concentration: 24%
Compound 4: middle estimate off by 11 percentage points, on the high side; low and high end bracket the measured number.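

Taking the methoxy group off the aromatic ring, ortho to a large group, gives in this assay a step of a number 9 percentage points lower from compound 3 to compound 4 (within the scatter), and the same kind of change on the core of compound 1 behaved alike: the same change on two cores in this assay, a number 7 percentage points lower (within the scatter) from compound 1 to compound 2 and a number 9 percentage points lower (within the scatter) from compound 3 to compound 4, 2 percentage points apart, within the scatter of two such steps So in this series, swapping methoxy for hydrogen on an aromatic carbon carried over from one core to the other as a small step, and neither pair gives any sign that this methoxy group matters for growth inhibition at the one concentration tested. This does not show that the change is harmless in general, since it rests on just two pairs, the methoxy group leaves from a different place in each pair, and a single concentration says nothing about how the compounds would compare at other concentrations.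

The compounds shown leave open whether an amine or a carboxylic acid in place of that methoxy group would move the number, or whether a longer chain would do so. They also leave open which part of the structure separates the two cores, since the pairs differ from each other in more than one place.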